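Chloro in place of hydrogen on compound 3

This account rests on a few compounds, and the source may have more. Where it says the series, first, only, none or still open, it means among the compounds named here.

In an ADME assay on MT4 cells (Homo sapiens) for cytotoxicity, read by MTT assay (on this read-out higher numbers stand for lower toxicity in this test and lower numbers for higher toxicity in this test), compound 3 (`O=C(CSc1nncnc1-c1cccc2ccccc12)Nc1ccccc1`) gives 154000 nM, within the scatter of compound 1 (`Cc1ccc(NC(=O)CSc2nncnc2-c2cccc3ccccc23)c(Br)c1`) at 166000 nM and of compound 2 (`CCOC(=O)c1ccc(NC(=O)CSc2nncnc2-c2cccc3ccccc23)c(Cl)c1`) at 150000 nM. Compound 4 (`O=C(CSc1nncnc1-c1cccc2ccccc12)Nc1ccccc1Cl`) has chloro in place of hydrogen on an aromatic carbon, ortho to a large group: chloro in place of hydrogen on an aromatic carbon. Among the compounds with values here, the one measured step at this ring is a 1.1-fold lower number from compound 1 to compound 3 (0.03 log units; within the scatter), phenyl in place of 2-bromo-4-methylphenyl, and it stays within the scatter. Compound 2 also holds a chloro group and is not separated from compound 3 either. No step beyond the scatter is therefore expected in this assay. Compound 4 is estimated at 150000 nM, with an expected range of 90000 nM to 240000 nM.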

Compound 4, half-maximal cytotoxic concentration: 63000 nM
The estimate for compound 4 lay 2.4-fold (0.38 log units) above the measured number; measured number outside the range, below it.
By their numbers in this assay, from the lowest: compound 4; then compounds 2, 3 and 1 (each within the scatter of the next).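

Chloro in place of hydrogen on an aromatic carbon, ortho to a large group, is the first change in this series to move the number beyond the scatter in this assay (a 2.4-fold lower number from compound 3 to compound 4 (0.39 log units; beyond the scatter)). Hydrogen in place of ethoxycarbonyl (a 2.4-fold lower number from compound 2 to compound 4 (0.38 log units; beyond the scatter)) and 2-chlorophenyl in place of 2-bromo-4-methylphenyl (a 2.6-fold lower number from compound 1 to compound 4 (0.42 log units; beyond the scatter)) show that a halogen on this ring does not by itself give the lower number: compound 1 and compound 2 both hold one and remain within the scatter of compound 3. No measurement shown accounts for these steps. On these data alone, whether fluoro, methoxy or an amine at this position would also lower the number remains open.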